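Naphthalene in place of ethylphenyl on the ketone side chain

The compounds below may be only part of what the source reports. "The series", "measured", "known", "first", "only" and "open" are said of these compounds alone.

Three chromene-type compounds sharing one core have been measured in a functional assay on SHEP cells (Homo sapiens) for antiproliferative activity, read by spectrophotometry and resazurin assay, with a stated time of 72 h; a higher number here means a weaker inhibitor, a lower number a stronger inhibitor. Compound 1 `CC(=O)CC1Oc2cc(O)ccc2C=C1c1ccc(O)cc1` gives 124000 nM. Compound 2 `CC(C)CC(=O)CC1Oc2cc(O)ccc2C=C1c1ccc(O)cc1` gives 139000 nM, and a 1.1-fold higher number from compound 1 to compound 2 (0.05 log units; within the scatter). Compound 3 `CCc1ccc(C(=O)CC2Oc3cc(O)ccc3C=C2c2ccc(O)cc2)cc1` gives 377000 nM, the highest of the three numbers; its nearest neighbour is compound 2, and the step of a 2.7-fold higher number from compound 2 to compound 3 (0.43 log units; beyond the scatter), while a 3.0-fold higher number from compound 1 to compound 3 (0.48 log units; beyond the scatter).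

Compound 4 `O=C(CC1Oc2cc(O)ccc2C=C1c1ccc(O)cc1)c1cccc2ccccc12` is not yet measured. The change from compound 3 is naphthalen-1-yl in place of 4-ethylphenyl on a carbonyl carbon. The two steps that bear on it are those in which an aromatic group replaced an alkyl group on the same carbonyl carbon, each raising the number modestly but beyond the scatter. Here one aromatic group replaces another, a smaller change than either of those, so the step of a 1.1-fold higher number from compound 3 to compound 4 (0.03 log units; within the scatter) is expected to stay within the scatter, or at most to lean slightly toward a higher number. Compound 4 is therefore estimated at 400000 nM, with a range from 150000 nM to 1000000 nM.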

Compound 4, half-maximal inhibitory concentration: 128000 nM
Compound 4: the middle estimate sits 3.1-fold (0.49 log units) above what was measured; measured number outside the range, below it.
By their numbers in this assay, from the lowest: compounds 1, 4 and 2 (each within the scatter of the next); then compound 3.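

In this assay, exchanging one aromatic group for another on the carbonyl carbon is not a neutral change, giving a 2.9-fold lower number from compound 3 to compound 4 (0.47 log units; beyond the scatter). The naphthalen-1-yl group also leaves the number level with those of the alkyl ketones, with a 1.1-fold lower number from compound 2 to compound 4 (0.04 log units; within the scatter) and a 1.0-fold higher number from compound 1 to compound 4 (0.01 log units; within the scatter), so among these four compounds an aromatic group on this carbon does not in itself go with a higher number, and compound 3 alone stands apart. Nothing available here accounts for this difference between the two aromatic groups.

Going by these compounds, whether the higher number of compound 3 belongs to its ethyl group or to its single aromatic ring stays open, and a plain phenyl group would separate the two. On these data alone, it is also open whether an amine, a carboxylic acid or a longer alkyl chain on this carbonyl carbon would move the number away from the level shared by compounds 1, 2 and 4.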